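This account rests on a few compounds, and the source may have more. Where it says the series, first, only, none or still open, it means among the compounds named here.

Measured in an ADME assay on a cell-free system (plasma, Rattus norvegicus) for protein binding:
- Compound 1 `NC(=O)c1ccc(-c2cccc3nc(-c4cncnc4)nc(NCc4ccccn4)c23)cc1`: > 99%
- Compound 2 `Nc1ncc(-c2nc(NCc3ccccn3)c3c(-c4ccccc4)cccc3n2)cn1`: > 99.5%

Compound 1 gives only a limit of the assay, not a number. Compound 2 also gives only a limit, > 99.5%, so its true value is not known.

Compound 3 `NS(=O)(=O)c1ccc(-c2nc(NCc3ccccn3)c3c(-c4ccccc4)cccc3n2)cn1` has 6-sulfamoylpyridin-3-yl in place of 2-aminopyrimidin-5-yl on an aromatic carbon. For the measured compounds named here, no measured pair shows what this swap does. The expected change, an at least 2.0-fold higher unbound fraction from compound 2 to compound 3 (0.30 log units; that floor lies within the scatter), is small and toward more free compound. For compound 3 the estimated value in this assay is 99%, with an expected range from 97% to 99.7%.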

Compound 3, plasma protein binding: > 99.5%
Compound 3 ended at the assay's limit; the forecaster's own chance of this, stated with the estimate: 50%; middle value at least 2.0-fold (0.30 log units) (unbound fraction) away from the limit.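

No step can be read from compound 2 to compound 3: both values are limits, not numbers. The compounds shown leave open whether 6-sulfamoylpyridin-3-yl in place of 2-aminopyrimidin-5-yl changes the result at all in this assay.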